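A benzyl group on the amide and cytotoxicity in lung cells

The compounds below may be only part of what the source reports. "The series", "measured", "known", "first", "only" and "open" are said of these compounds alone.

Compound 3, `COc1ccc(OC)c(-c2cc(-c3ccc(C(=O)N(C)C)s3)on2)c1`, was tested in a functional assay on A549 cells (Homo sapiens) for cytotoxicity, read by XTT assay, with a stated time of 72 h; on this read-out lower numbers stand for stronger inhibition and higher numbers for weaker inhibition. In this assay compound 3 gives > 30000 nM, which is a limit of the assay rather than a number. Two related compounds were run in the same way. Compound 1, `O=C1C=CC(=O)C(c2cc(-c3ccc(C(=O)N4CCC(C(F)(F)F)CC4)s3)on2)=C1`, gives > 30000 nM in this assay, again a limit. Compound 2, `O=C1C=CC(=O)C(c2cc(-c3ccc(C(=O)N4CCCCC4)s3)on2)=C1`, gives > 30000 nM in this assay, also a limit. For the measured compounds named here, the only step between measured compounds that differ in a single place is a step that the two limits leave unreadable from compound 1 to compound 2, hydrogen in place of trifluoromethyl on a saturated ring carbon; its size cannot be read because both ends of it sit at the limit of > 30000 nM in this assay, at which 3 of the 3 values shown sit. Compound 3 thus stands at the same limit as every other value shown, and nothing separates it from them.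

Compound 4, `COc1ccc(OC)c(-c2cc(-c3ccc(C(=O)N(C)Cc4ccccc4)s3)on2)c1`, differs from compound 3 by phenyl in place of hydrogen on a saturated chain carbon bound to an amide-type nitrogen. No measured step touches this part of the molecule, and the one step that is shown concerns a different position and is unreadable in size. The expectation for this assay is therefore no step beyond the scatter, and most likely a further limit rather than a number. The estimated step is a step that the limit leaves unreadable from compound 3 to compound 4. Compound 4 is expected to give about 40000 nM in this assay, with a range from 10000 nM to 200000 nM.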

Compound 4, half-maximal inhibitory concentration: > 30000 nM
Compound 4: only a limit was reported (the forecaster's own chance of this, stated with the estimate: 80%); the middle value lies beyond the limit too.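

The size of the step from compound 3 to compound 4 cannot be read, as both compounds stop at a limit and give no number: the limit of > 30000 nM in this assay, at which 4 of the 4 values shown sit.

The compounds shown leave open whether phenyl in place of hydrogen, or any other change among them, alters cytotoxicity in these lung cells at all.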